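The source may report more compounds than this note shows. Statements on the series, on what has been measured and on what is new or still open speak of the compounds shown alone.

In an assay on isolated protein for inhibition of steroid 5-alpha-reductase (Rattus norvegicus) (on this read-out lower numbers stand for stronger inhibition and higher numbers for weaker inhibition), compound 1 `COc1ccccc1N1CCN(CCC(Oc2ccc(NC(=O)c3ccccc3OCCCC(=O)O)cc2)c2ccccc2)CC1` gives 730 nM, compound 2 `COc1ccccc1N1CCN(CCC(Oc2ccc(NC(=O)c3ccccc3OCCCC(=O)O)cc2)c2ccc(CC(C)C)cc2)CC1` gives 96 nM, and compound 3 `COc1ccccc1N1CCN(CCC(Oc2ccc(C(=O)Nc3ccccc3OCCCC(=O)O)cc2)c2ccc(C)cc2)CC1` gives 67 nM. Compound 3 thus holds the lowest of the three numbers, yet compound 2 sits within the scatter of it; only compound 1 stands clearly apart. Compound 4 `COc1ccc(C(CCN2CCN(c3ccccc3OC)CC2)Oc2ccc(C(=O)Nc3ccccc3OCCCC(=O)O)cc2)cc1` differs from compound 3 by methoxy in place of methyl on an aromatic carbon. For the measured compounds named here, no measured pair shows exactly this change. Going by the values given here, the only measured step, a 7.6-fold lower number from compound 1 to compound 2 (0.88 log units; beyond the scatter), placed a different group on an aromatic carbon, and it lowered the number. Because that step a 7.6-fold lower number from compound 1 to compound 2 (0.88 log units; beyond the scatter) concerned another group, it offers only weak guidance, and for compound 4 the expected step is a 1.2-fold higher number from compound 3 to compound 4 (0.08 log units; within the scatter), not beyond the scatter. The estimate for compound 4 is 80 nM, with a range from 30 nM to 220 nM.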

Compound 4, half-maximal inhibitory concentration: 170 nM
Estimate against measurement, compound 4: 2.1-fold (0.33 log units) below; low and high end bracket the measured number.
By their numbers in this assay, from the lowest: compounds 3, 2 and 4 (each within the scatter of the next, the first and the last beyond it); then compound 1.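

In this assay the change from 4-methylphenyl to 4-methoxyphenyl gives a 2.5-fold higher number from compound 3 to compound 4 (0.40 log units; beyond the scatter) and so shows that this position responds even to a swap of methyl for methoxy. For the compounds shown here, the only earlier step here put isobutyl in place of hydrogen and lowered the number, whereas this one raises it, so a new group at this place need not help. Nothing available explains the rise. On these data alone, what a hydroxyl or a fluorine at this place would give remains open, as does the effect of methoxy on the core of compound 1.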